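Growth inhibition notes: from compound 2 to compound 4

A few compounds are considered here, and "the series" means these few. Any claim that something is new, unique, unknown or untested is made for them only; others in the source may bear on it.

Measured in a functional assay on MCF7 cells (Homo sapiens) for inhibition, read by fluorescence, with a stated time of 72 h; on this read-out higher numbers stand for weaker inhibition of growth and lower numbers for stronger inhibition of growth:
- compound 1 `COc1ccc(Nc2nc(N[C@H]3CC[C@H](N)CC3)nc3c2ncn3CCC(C)C)c(OC)c1`: 6300 nM
- compound 2 `COc1ccc(Cn2cnc3c(Nc4cccc(Cl)c4)nc(N[C@H]4CC[C@H](N)CC4)nc32)cc1`: 4800 nM
- compound 3 `CC(C)CCn1cnc2c(NCc3cccc(Cl)c3)nc(N[C@H]3CC[C@H](N)CC3)nc21`: 4700 nM

The values of compound 2 and of compounds 1 and 3 lie within the scatter of each other, so the three compounds are not separated in this assay.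

The next compound is compound 4 `CCCCCCn1cnc2c(Nc3cccc(Cl)c3)nc(N[C@H]3CC[C@H](N)CC3)nc21`. Relative to compound 2 it carries pentyl in place of 4-methoxyphenyl on a saturated chain carbon bound to an aromatic nitrogen.

Among the compounds with values here, no measured step covers this place. Within the data shown here, the only measured step, a 1.3-fold lower number from compound 1 to compound 3 (0.13 log units; within the scatter), lies within the scatter, and its change is on a nitrogen on an aromatic ring. Compound 2 differs from compound 3 in its group at this place and also elsewhere, and its value lies within the scatter of the value of compound 3, 4700 nM. No step beyond the scatter is therefore expected, although the evidence is thin. The expected step is a 1.1-fold lower number from compound 2 to compound 4 (0.03 log units; within the scatter).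

The estimate for compound 4 is 4500 nM, with an expected range of 2000 nM to 10000 nM.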

Compound 4, concentration for 50% growth inhibition: 2700 nM
Beside the measured number, compound 4's estimate is 1.7-fold (0.22 log units) above it, within the range that was stated.
By their numbers in this assay, from the lowest: compounds 4, 3, 2 and 1 (each within the scatter of the next, the first and the last beyond it).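

Within the data shown here, this is the first measured step at this place, on a saturated chain carbon bound to an aromatic nitrogen: in this assay, the step of a 1.8-fold lower number from compound 2 to compound 4 (0.25 log units; within the scatter) lies within the scatter. The 4-methoxyphenyl takes its six-membered aromatic ring and its hydrogen-bond acceptor with it, pentyl enters, and the two compounds are still not separated, so neither the ring nor the acceptor is needed in this pair to hold growth inhibition at this level. No evidence at hand accounts for this result.

From the compounds shown here alone, whether a hexyl chain carrying an amine or a carboxylic acid, or a longer chain such as octyl, would give a step beyond the scatter remains open. Also open, going by these compounds, is whether pentyl in place of 4-methoxyphenyl gives the same result when the group on the nitrogen on the aromatic ring is 3-chlorobenzyl.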